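The source may hold more compounds than are shown below. What is called first, only, known or untested is meant among the compounds shown, and "the series" means these compounds.

Compound 3 `COc1cc(NS(=O)(=O)c2ccc(C)cc2[N+](=O)[O-])c2ncccc2c1` is one of three measured members of a small series that also contains compound 1 `Cc1ccc2cccc(NS(=O)(=O)c3ccccc3[N+](=O)[O-])c2n1` and compound 2 `Cc1ccc2cccc(NS(=O)(=O)c3ccc(C(F)(F)F)cc3[N+](=O)[O-])c2n1`. In an assay on HUVEC cells for inhibition of transcription factor p65 (Homo sapiens) (on this read-out lower numbers stand for smaller maximal responses and higher numbers for larger maximal responses), compound 1 gives > 90%, which is a limit of the assay rather than a number. Compound 2 gives > 90% in this assay, again a limit. Compound 3 gives > 90% in this assay, also a limit. The step that the two limits leave unreadable from compound 1 to compound 2 is therefore unreadable, since all three values sit at the limit of > 90% in this assay, at which 3 of the 3 values shown sit. Compound 4 `COc1cc(NS(=O)(=O)c2ccc(C)cc2[N+](=O)[O-])c2nc(C)ccc2c1` differs from compound 3 by methyl in place of hydrogen on an aromatic carbon. Among the measured compounds shown here, no measured step bears on this change, so no step beyond the scatter is expected in this assay. Compound 4 is estimated at 95%, within 88% to 100%, meaning an expected step that the limit leaves unreadable from compound 3 to compound 4.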

Compound 4, largest response reached (reported as efficacy), in percent of the reference or control that the assay uses: > 90%
Compound 4 ended at the assay's limit; the forecaster's own chance of this, stated with the estimate: 85%; the middle value lies beyond the limit too.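

No new step can be read from compound 3 to compound 4, as both values are limits of the assay: the limit of > 90% in this assay, at which 4 of the 4 values shown sit. The compounds shown leave open whether methyl in place of hydrogen changes the response in this assay at all.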